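Chloro to Nitro on a Fused Aromatic Ring

The compounds below may be only part of what the source reports. "The series", "measured", "known", "first", "only" and "open" are said of these compounds alone.

Of the compounds shown here, three sharing one core have been measured. Compound 1 `Nc1ccccc1NC(=O)c1ccc(CSC(=S)N2CCc3ccccc32)cc1` gives 85.4% in a functional assay on A-375 cells (Homo sapiens) for antiproliferative activity, read by CCK-8 assay, with a stated time of 72 h, tested at 8 uM; a higher number here means a stronger effect of the compound at the concentration tested, a lower number a weaker effect. Compound 2 `Nc1ccccc1NC(=O)c1ccc(CSC(=S)N2CCc3cc(Cl)ccc32)cc1` gives 82.3% in this assay, and compound 3 `CC1CCCCN1C(=S)SCc1ccc(C(=O)Nc2ccccc2N)cc1` gives 85.2%. Compound 2 sits at the bottom of these three numbers, yet both gaps, a number 3.1 percentage points lower from compound 1 to compound 2 (within the scatter) and a number 2.9 percentage points higher from compound 2 to compound 3 (within the scatter), fall within the scatter, so no real ordering can be drawn from them.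

Compound 4 `Nc1ccccc1NC(=O)c1ccc(CSC(=S)N2CCc3cc([N+](=O)[O-])ccc32)cc1` has not yet been measured. It differs from compound 2 by nitro in place of chloro on an aromatic carbon. Going by the values given here, the only measured step that touches the same spot is a number 3.1 percentage points lower from compound 1 to compound 2 (within the scatter), which placed a chloro there and changed nothing beyond the scatter. Among the compounds with values here, no measured step involves a nitro, so the effect of this particular group is unknown here. Given that the whole set, including a number 0.2 percentage points lower from compound 1 to compound 3 (within the scatter), stays flat, the expected step for compound 4 is a number 0.3 percentage points lower from compound 2 to compound 4 (within the scatter), that is, none beyond the scatter. Compound 4 is therefore estimated at 82%, with a range from 70% to 92%.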

Compound 4, a percentage reported as inhibition, at one concentration (the size of the read-out at that concentration, not a potency): 29.5%
Compound 4: the middle estimate sits 52.5 percentage points above what was measured; the whole stated range lies above it.
By their numbers in this assay, from the lowest: compound 4; then compounds 2, 3 and 1 (each within the scatter of the next).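

This position is not indifferent after all: in this assay chloro in place of hydrogen left the read-out within the scatter, but nitro in place of chloro gives a number 52.8 percentage points lower from compound 2 to compound 4 (beyond the scatter) and nitro in place of hydrogen gives a number 55.9 percentage points lower from compound 1 to compound 4 (beyond the scatter) on the same aromatic carbon. Going by these compounds alone, the flat picture from the earlier compounds therefore held for hydrogen and chloro only, not for whatever this carbon carries. No measurement shown here accounts for the size of this drop.

On these data alone, whether the loss belongs to nitro alone, or would also appear with an amine, a nitrile or a methoxy group on this carbon, remains open. Also open, as far as these compounds go, is what nitro would do on another carbon of this ring, and how compound 4 would behave at other concentrations, since a reading at one concentration is not a potency.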